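This account rests on a few compounds, and the source may have more. Where it says the series, first, only, none or still open, it means among the compounds named here.

Compound 1, `CCC(=O)N(C)c1ccc2[nH]c(-c3n[nH]c4ccccc34)cc2n1`, is the smaller of two measured compounds: in a functional assay on KB cells (Homo sapiens) for antiproliferative activity, read by MTT assay, with a stated time of 72 h (on this read-out lower numbers stand for stronger inhibition and higher numbers for weaker inhibition), compound 1 gives 9300 nM. Compound 2, `CN(c1ccc2[nH]c(-c3n[nH]c4ccccc34)cc2n1)S(=O)(=O)c1ccc(Br)cc1`, carries a larger group on the same nitrogen and in this assay compound 2 gives 7150 nM. Going by the values given here, the only step measured so far, a 1.3-fold lower number from compound 1 to compound 2 (0.11 log units; within the scatter), stays within the scatter, so compound 2 has the lowest of the two numbers without being separable from compound 1.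

Compound 3, `CN(c1ccc2[nH]c(-c3n[nH]c4ccccc34)cc2n1)S(=O)(=O)c1ccc(OC(F)(F)F)cc1`, is not yet measured. It differs from compound 2 only at the far end of the ring that was introduced in that step: trifluoromethoxy in place of bromo on an aromatic carbon. Among the compounds with values here, no measured step touches this position, and the one step known, a 1.3-fold lower number from compound 1 to compound 2 (0.11 log units; within the scatter), concerns the group on the nitrogen rather than the substituent on the phenyl, so it offers no direct guide. With the shared core, the nitrogen substitution and the sulfonyl-bearing ring all unchanged, the expectation is a step of a 1.0-fold lower number from compound 2 to compound 3 (0.01 log units; within the scatter), that is no change beyond the scatter. For compound 3 the expected value in this assay is therefore 7000 nM, within a range of 3000 nM to 16000 nM.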

Compound 3, half-maximal inhibitory concentration: 1330 nM
Beside the measured number, compound 3's estimate is 5.3-fold (0.72 log units) above it; the measured number lies below the stated range.
By their numbers in this assay, from the lowest: compound 3; then compounds 2 and 1 (each within the scatter of the next).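

Going by these compounds alone, the far end of the sulfonyl-bearing ring is a position that responds in this assay: on an aromatic carbon para to a large group, trifluoromethoxy in place of bromo gives a 5.4-fold lower number from compound 2 to compound 3 (0.73 log units; beyond the scatter), the first step here that lies beyond the scatter. The earlier step changed the group on the nitrogen and stayed within the scatter, so a small change at the end of the phenyl ring has shown a clearer difference than the larger exchange of propanoyl for (4-bromophenyl)sulfonyl. Trifluoromethoxy has more heavy atoms than bromo and adds a hydrogen-bond acceptor, but nothing measured here shows which feature of the swap, if any, accounts for the lower number.

A single swap cannot show whether this result is specific to trifluoromethoxy, or how a hydrogen, a methoxy group, a trifluoromethyl group, an amine or a carboxylic acid would read at the same place. It also leaves open whether the step would keep its size if the methyl on the nitrogen gave way to a longer chain.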